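The source may report more compounds than this note shows. Statements on the series, on what has been measured and on what is new or still open speak of the compounds shown alone.

Both measured compounds in this set were tested in a functional assay on CCRF-CEM cells (Homo sapiens) for inhibition, read by MTT assay, with a stated time of 2 days, tested at 10 uM; a higher number here means more inhibition at the concentration tested (going by the name of the read-out), a lower number less inhibition. Compound 1, `COc1ccc(-c2cn(-c3ccc(O)c(C(=O)Nc4cccc(C(F)(F)F)c4)c3)nn2)cc1`, gives 12% in this assay. Compound 2, `COc1ccc(OC)c(-c2cn(-c3ccc(O)c(C(=O)OCCCc4ccccc4)c3)nn2)c1`, gives 5% in this assay. Of the two figures, compound 2 stands at the bottom, yet its gap to compound 1 falls within the usual scatter of repeated measurements, so the two compounds cannot be told apart on these numbers. The next compound, compound 3, `O=C(OCCCc1ccccc1)c1cc(-n2cc(-c3cccc(O)c3)nn2)ccc1O`, has not yet been measured. It differs from compound 2 in one place: 3-hydroxyphenyl in place of 2,5-dimethoxyphenyl on an aromatic carbon. For the measured compounds named here, no measured pair in this set differs in a single place, so there is no earlier step to compare against; what is known is only that both measured compounds sit at the low end of the inhibition scale. On that basis the expected change is a number 3 percentage points higher from compound 2 to compound 3 (within the scatter), meaning no movement beyond the scatter in either direction. Compound 3 is therefore estimated to give 8% in this assay, with a range from -5% to 25%.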

Compound 3, a percentage reported as inhibition, at one concentration (the size of the read-out at that concentration, not a potency): 9%
Compound 3: middle estimate off by 1 percentage points, on the low side, and the stated range covers the measured number.
By their numbers in this assay, from the lowest: compounds 2, 3 and 1 (each within the scatter of the next).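

For the compounds shown here, on the aromatic carbon of the five-membered ring with 3 nitrogen, next to the ring nitrogen, 3-hydroxyphenyl in place of 2,5-dimethoxyphenyl gives a number 4 percentage points higher from compound 2 to compound 3 (within the scatter) in this assay, and this is the first single-place comparison in the set. The position therefore accepts an exchange from a group of 10 heavy atoms with 0 hydrogen-bond donors to one of 7 heavy atoms with 1 hydrogen-bond donor, with no movement beyond the scatter and with the number still at the low end of the scale. Nothing available explains this outcome or connects it to any property of either group.

Because the step changes the ring's substituents and their arrangement together, the compounds shown do not separate the gain of the hydroxyl from the loss of the two methoxy groups. On these data alone, it also remains open whether an amine or a carboxylic acid on this phenyl ring would lift the inhibition clear of the scatter, and whether 3-hydroxyphenyl would behave the same way with an amide in place of the ester.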